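The compounds below may be only part of what the source reports. "The series", "measured", "known", "first", "only" and "open" are said of these compounds alone.

Measured so far in a functional assay on MV4-11 cells (Homo sapiens) for inhibition, read by luminescence, with a stated time of 3 days; on this read-out higher numbers stand for weaker inhibition of growth and lower numbers for stronger inhibition of growth
compound 1 `CC(=O)N1CCN(C(=O)[C@@H]2CC[C@@H](C)N2C(=O)C2=C(C(C)C)N3C(=N[C@@](C)(c4ccc(Cl)cc4)[C@H]3c3ccc(Cl)cc3)S2)CC1` | 270 nM
compound 2 `CC[C@@H]1CC[C@@H](C(=O)N2CCOCC2)N1C(=O)C1=C(C(C)C)N2C(=N[C@@](C)(c3ccc(Cl)cc3)[C@H]2c2ccc(Cl)cc2)S1` | 94 nM

Compound 2 holds the lower of the two numbers at 94 nM and its gap to compound 1 at 270 nM lies beyond the scatter. Compound 3 `CC[C@@H]1CC[C@@H](C(=O)N2CCN(C(C)=O)[C@@H](C)C2)N1C(=O)C1=C(C(C)C)N2C(=N[C@@](C)(c3ccc(Cl)cc3)[C@H]2c2ccc(Cl)cc2)S1` departs from compound 2 in one place, on a carbonyl carbon, with a group of 10 heavy atoms (7 carbon, 2 nitrogen, 1 oxygen; one six-membered non-aromatic ring with 2 hetero atoms) in place of a group of 6 heavy atoms (4 carbon, 1 nitrogen, 1 oxygen; one six-membered non-aromatic ring with 2 hetero atoms), on a carbonyl carbon as the counted difference. The morpholin-4-yl group leaves and the entering group brings one defined stereocentre. Among the compounds with values here, no two measured compounds differ in one place only, so the data hold no step for this change. In this assay no step beyond the scatter is expected, and neither direction is clearly favoured. The expected size is a 1.1-fold lower number from compound 2 to compound 3 (0.04 log units; within the scatter) as a working estimate. The estimate rests on compound 2 at 94 nM as its anchor. For compound 3 the estimated value is 85 nM with an expected range from 35 nM to 210 nM as the working bracket.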

Compound 3, concentration for 50% growth inhibition: 120 nM
Estimate against measurement, compound 3: 1.4-fold (0.15 log units) below, and the stated range covers the measured number.
By their numbers in this assay, from the lowest: compounds 2 and 3 (each within the scatter of the next); then compound 1.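

In this assay, within the data shown here, the only step at this position so far is a 1.3-fold higher number from compound 2 to compound 3 (0.11 log units; within the scatter) and lies within the scatter. On a carbonyl carbon whose other neighbour is a saturated ring carbon, the morpholin-4-yl group can thus give way to the larger group of compound 3, with its added heavy atoms, double bond outside aromatic rings and defined stereocentre, without a change that this read-out can separate from the scatter. The data give no reason for this result.

As far as these compounds go, whether this holds for a different kind of group at the same carbonyl carbon, such as a carboxylic acid or an open-chain amine, remains open. Also open, from the compounds shown here alone, is how the opposite configuration at the new stereocentre, or the same ring without its methyl group, would read.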